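Fluoro to cyano on the aryl of compound 2

This account rests on a few compounds, and the source may have more. Where it says the series, first, only, none or still open, it means among the compounds named here.

Measured so far:
compound 1 `Cc1nncc(C#Cc2ccccc2)n1` — "not active" (no number reported)
compound 2 `Cc1cnnc(C#Cc2cccc(F)c2)n1` — 96 nM

In a functional assay on CHO-K1 cells for antagonist activity at metabotropic glutamate receptor 5 (Homo sapiens), read by calcium flux (a higher number here means a weaker inhibitor, a lower number a stronger inhibitor), compound 2 gives 96 nM. In this assay, going by the values given here, compound 1 gives "not active" (no number reported), a report without a number, so compound 2 holds the only number in this assay; nothing can be said about the size of the gap between them, and no step between measured compounds is available.

Compound 3 `Cc1cnnc(C#Cc2cccc(C#N)c2)n1` is not yet measured. It differs from compound 2 by cyano in place of fluoro on an aromatic carbon.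

Among the compounds with values here, with no measured step to lean on, the expectation for the step from fluoro to cyano is a change within the scatter, or at most a small gain, with the step from compound 2 to compound 3 estimated as a 1.6-fold lower number from compound 2 to compound 3 (0.20 log units; within the scatter). Compound 3 is therefore estimated at 60 nM, with a range from 20 nM to 200 nM.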

Compound 3, half-maximal inhibitory concentration: 52 nM
For compound 3 the middle estimate is 1.2-fold (0.06 log units) above the measured one; the measured number falls inside the stated range.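

In this assay the aromatic carbon carrying these groups takes cyano in place of fluoro, with a 1.8-fold lower number from compound 2 to compound 3 (0.27 log units; within the scatter), which gives the series its first readable step between compounds differing in one place. The two numbers cannot be told apart, so at this place a measurable potency is kept when the single fluorine gives way to a group of two heavy atoms with a triple bond and a hydrogen-bond acceptor. No available measurement bears on why the two groups read alike.

Open, from the compounds shown here alone, is whether an amine, a carboxylic acid or a methoxy group would read the same at this place. Also open, going by these compounds, is how fluoro and cyano each compare with plain hydrogen on the core of compound 2.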